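Methyl on the saturated ring: compound 1 to compound 3

The source may report more compounds than this note shows. Statements on the series, on what has been measured and on what is new or still open speak of the compounds shown alone.

Measured so far:
compound 1 `CC(C)(C)c1ccc2[nH]c(N3CCN(c4ncccc4Cl)CC3)nc2c1` — 136 nM
compound 2 `C[C@@H]1CN(c2ncccc2Cl)CCN1c1nc2ccc(C(C)(C)C)cc2[nH]1` — 90.4 nM

In a functional assay on HEK293 cells for antagonist activity at transient receptor potential cation channel subfamily V member 1 (Homo sapiens), read by FLIPR (a higher number here means a weaker inhibitor, a lower number a stronger inhibitor), compound 1 gives 136 nM, the higher of the two numbers; compound 2 gives 90.4 nM, and the gap between them lies within the scatter. Compound 3 `C[C@H]1CN(c2ncccc2Cl)CCN1c1nc2cc(C(C)(C)C)ccc2[nH]1` is not yet measured. It differs from compound 1 by methyl in place of hydrogen on a saturated ring carbon. Compound 2 also carries a methyl on the saturated ring and shows no shift beyond the scatter, so for compound 3 the expected step of a 1.2-fold lower number from compound 1 to compound 3 (0.09 log units; within the scatter) is small, near none. Compound 3 is estimated at 110 nM, in the range 40 nM to 350 nM.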

Compound 3, half-maximal inhibitory concentration: 948 nM
For compound 3 the middle estimate is 8.6-fold (0.94 log units) below the measured one; measured number outside the range, above it.
By their numbers in this assay, from the lowest: compounds 2 and 1 (each within the scatter of the next); then compound 3.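

In this assay, methyl in place of hydrogen on this saturated ring carbon, next to the ring nitrogen, is not a neutral change: it gives a 7.0-fold higher number from compound 1 to compound 3 (0.84 log units; beyond the scatter). Compound 2 also carries a methyl on the saturated ring yet stays within the scatter of compound 1, so a methyl there does not always cost activity. Nothing measured here gives a cause for the step.

Still open, as far as these compounds go, is how an ethyl or a hydroxymethyl on this same carbon would read, and whether a fluorine would be tolerated there.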